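The compounds below may be only part of what the source reports. "The series", "measured", "known", "first", "only" and "open" are said of these compounds alone.

Compound 1 `COc1ccc(Br)cc1Nc1cc(NC(=O)Nc2c(Cl)cccc2Cl)ncn1`: 53% in a functional assay on HCC827 cells (Homo sapiens) for inhibition, read by MTT assay, with a stated time of 48 h, tested at 10 uM; on this read-out higher numbers stand for more inhibition at the one concentration tested (going by the name of the read-out) and lower numbers for less inhibition.
Compound 2 `COc1cc(NC(=O)Nc2cc(Nc3cc(Br)ccc3OC)ncn2)cc(OC)c1`: 76.3%.
Compound 3 `COc1ccc(F)cc1Nc1cc(NC(=O)Nc2c(Cl)cccc2Cl)ncn1`: 78%.

Compound 2 stands second highest of the three numbers in this assay; compound 3 sits close, within the scatter, while compound 1 lies well below, as the step of a number 23.3 percentage points higher from compound 1 to compound 2 (beyond the scatter) shows. Compound 4 `COc1cc(NC(=O)Nc2cc(Nc3cc(C)cc(F)c3)ncn2)cc(OC)c1` differs from compound 2 in one place: 3-fluoro-5-methylphenyl in place of 5-bromo-2-methoxyphenyl on a nitrogen on an aromatic ring. Among the compounds with values here, of the measured steps, only a number 25 percentage points higher from compound 1 to compound 3 (beyond the scatter) touches a related change, fluoro in place of bromo, and it raised inhibition; the loss of the methoxy group and the new substitution pattern have no counterpart among the measured compounds. A step of at most modest size is therefore expected for compound 4, more likely upward than downward, a number 3.7 percentage points higher from compound 2 to compound 4 (within the scatter). Compound 4 is expected to give about 80%, within 58% to 95%.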

Compound 4, a percentage reported as inhibition, at one concentration (the size of the read-out at that concentration, not a potency): 62.1%
For compound 4 the middle estimate is 17.9 percentage points above the measured one; low and high end bracket the measured number.
By their numbers in this assay, from the lowest: compounds 1 and 4 (each within the scatter of the next); then compounds 2 and 3 (each within the scatter of the next).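

In this assay the swap of 5-bromo-2-methoxyphenyl for 3-fluoro-5-methylphenyl on this nitrogen gives a number 14.2 percentage points lower from compound 2 to compound 4 (beyond the scatter) and so shows that this position affects the read-out. The rise seen with fluoro in place of bromo in a number 25 percentage points higher from compound 1 to compound 3 (beyond the scatter) does not carry over to this larger change, in which bromo and methoxy leave while fluoro and methyl enter. No supporting data here bear on why the number fell.

Which of these single differences carries the step remains open. So does how this ring would read with an amine in place of the methyl.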